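This account rests on a few compounds, and the source may have more. Where it says the series, first, only, none or still open, it means among the compounds named here.

Measured compounds:

Compound 1 `O=[N+]([O-])c1ccc(NC(=S)N2CCN(S(=O)(=O)c3sccc3-c3ccccc3Oc3ccc(O)c(O)c3)CC2)cc1`. In an ADME assay on HEK-293T cells (Homo sapiens) for cytotoxicity, read by CCK-8 assay, with a stated time of 48 h (on this read-out higher numbers stand for weaker inhibition and lower numbers for stronger inhibition), compound 1 gives > 20000 nM, which is a limit of the assay rather than a number.
Compound 2 `COc1ccc(Oc2ccc([N+](=O)[O-])cc2-c2ccsc2S(=O)(=O)N2CCN(C(=O)Nc3ccc([N+](=O)[O-])cc3)CC2)cc1OC`. In this assay compound 2 gives > 20000 nM, again a limit.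
Compound 3 `COc1ccc(Oc2ccccc2-c2ccsc2S(=O)(=O)N2CCN(C(=S)Nc3ccc([N+](=O)[O-])cc3)CC2)cc1OC`. In this assay compound 3 gives > 20000 nM, also a limit.

Compound 1 therefore stands where every value in this set stands: the limit of > 20000 nM in this assay, at which 3 of the 3 values shown sit. Going by the values given here, the one step between measured compounds that differ in a single place, a step that the two limits leave unreadable from compound 1 to compound 3, cannot be read in size, since both ends are limits.

Compound 4 `O=S(=O)(c1sccc1-c1ccccc1Oc1ccc(O)c(O)c1)N1CCN(C(=S)Nc2ccc(Cl)cc2)CC1` is not yet measured. It differs from compound 1 by chloro in place of nitro on an aromatic carbon. Among the compounds with values here, no measured step exchanges chloro for nitro, so no step bears directly on this change; the only comparison available, from compound 1 to compound 3, is unreadable.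

The expectation for compound 4 is accordingly that this assay again reports a limit, with an estimated step that the limit leaves unreadable from compound 1 to compound 4 that is no more than the usual scatter. Compound 4 is estimated at 30000 nM, within 15000 nM to 80000 nM.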

Compound 4, half-maximal inhibitory concentration: > 50000 nM
Compound 4: only a limit was reported (the forecaster's own chance of this, stated with the estimate: 85%); at least 1.6-fold (0.22 log units) between middle value and limit.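

In this assay compound 4 gives > 50000 nM, a limit and not a number. Compound 1 also sits at a limit, so the exchange of nitro for chloro between compound 1 and compound 4 cannot be read in size. The compounds shown leave open what actual value any of them would give, and whether chloro or nitro goes with stronger inhibition.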